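The source may report more compounds than this note shows. Statements on the series, on what has been measured and on what is new or still open speak of the compounds shown alone.

Of the compounds shown here, two of a shared core have been measured in a functional assay on U-87MG ATCC cells for antiproliferative activity against U-87 MG (Homo sapiens), read by MTT assay, with a stated time of 48 h, tested at 100 uM; a higher number here means a weaker effect of the compound at the concentration tested, a lower number a stronger effect. Compound 1, with the structure `Cc1nc(-c2ccc(Cl)cc2)sc1C(=O)CSc1nc(-c2ccccc2)c(C#N)c(=O)[nH]1`, gives 11.4%. Compound 2, with the structure `COc1ccc(-c2nc(C)c(C(=O)CSc3nc(N)c(C#N)c(-c4ccccc4)n3)s2)cc1`, gives 5.25% in this assay. Of the two numbers recorded, that of compound 1 is the one at the top, but the gap to compound 2 lies within the usual scatter of such measurements, so the two compounds cannot be told apart on these values.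

The next compound to be measured is compound 3, with the structure `Cc1nc(-c2ccc(Cl)cc2)sc1C(=O)CSc1nc(-c2cccc(Cl)c2)c(C#N)c(=O)[nH]1`. It differs from compound 1 in one place: chloro in place of hydrogen on an aromatic carbon. The change sits on an aromatic carbon of a six-membered aromatic ring of carbon only, and read one bond further out it is phenyl becoming 3-chlorophenyl.

Going by the values given here, no pair of measured compounds shows the effect of this change, and compound 2 differs from compound 1 elsewhere, so no direction can be drawn from it. The step from compound 1 to compound 3 is expected to be no larger than the scatter, a number 0.6 percentage points higher from compound 1 to compound 3 (within the scatter). Compound 3 is therefore expected to give about 12% in this assay, between 3% and 25%.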

Compound 3, a percentage reported as activity, at one concentration (the size of the read-out at that concentration, not a potency): 12.5%
Compound 3: the middle estimate sits 0.5 percentage points below what was measured; measured number inside the range.
By their numbers in this assay, from the lowest: compounds 2, 1 and 3 (each within the scatter of the next).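

In this assay, going by these compounds alone, the swap of phenyl for 3-chlorophenyl gives the first reading at this position of the core of compound 1, and it amounts to a number 1.1 percentage points higher from compound 1 to compound 3 (within the scatter). Chloro in place of hydrogen on this aromatic carbon, meta to a large group, therefore leaves the two compounds indistinguishable on this read-out, and this single pair gives no sign that the position responds to this change in either direction. No measured information is available to explain this result.

The compounds shown leave open whether this lack of a measurable step is particular to chloro or extends to other groups on the same aromatic carbon, such as an amine, a carboxylic acid, a methoxy group or a longer alkyl chain. They also leave open whether chloro would give a similar reading on the core of compound 2, where the nitrile-bearing ring carries an amine in place of the carbonyl and the other aromatic ring carries methoxy in place of chloro.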